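Swapping methyl for fluoro on compound 1

The compounds below may be only part of what the source reports. "The series", "measured", "known", "first", "only" and "open" are said of these compounds alone.

Results in a functional assay on NCI-H460 cells (Homo sapiens) for antiproliferative activity, read by MTT assay, with a stated time of 48 h; on this read-out lower numbers stand for stronger inhibition and higher numbers for weaker inhibition:

Compound 1 `CCCCC1(O)C(=O)Nc2ccc(Nc3ccc(C)cc3)cc21`: 31800 nM
Compound 2 `Cc1ccc(Nc2ccc3c(c2)C(O)(CCC(C)C)C(=O)N3)cc1`: 22700 nM
Compound 3 `CCCCCCC1(O)C(=O)Nc2ccc(Nc3ccc(C)cc3)cc21`: > 100000 nM (a limit, not a number)

Going by the values given here, only two of these values are true numbers, and they lie within the scatter of each other, with a 1.4-fold lower number from compound 1 to compound 2 (0.15 log units; within the scatter). Compound 1 therefore stands level with compound 2. The value of compound 3 is a limit.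

Compound 4 `CCCCC1(O)C(=O)Nc2ccc(Nc3ccc(F)cc3)cc21` changes compound 1 in one place: fluoro in place of methyl on an aromatic carbon. This is fluoro in place of methyl on an aromatic carbon, so 4-methylphenyl becomes 4-fluorophenyl.

Among the compounds with values here, none of the measured steps bears directly on this change, as all of them alter the saturated chain. They are a 1.4-fold lower number from compound 1 to compound 2 (0.15 log units; within the scatter), an at least 3.1-fold higher number from compound 1 to compound 3 (0.49 log units; beyond the scatter) and an at least 4.4-fold higher number from compound 2 to compound 3 (0.64 log units; beyond the scatter).

Within the data shown here, since compound 1 gives 31800 nM and no measured step touches this carbon, no step beyond the scatter is expected in this assay. The expected step is a 1.1-fold lower number from compound 1 to compound 4 (0.03 log units; within the scatter). Compound 4 is estimated at 30000 nM, with an expected range from 10000 nM to 90000 nM.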

Compound 4, half-maximal inhibitory concentration: 32500 nM
Estimate against measurement, compound 4: 1.1-fold (0.03 log units) below; the range from low to high includes it.
By their numbers in this assay, from the lowest: compounds 2, 1 and 4 (each within the scatter of the next). At a limit, above all of these: compound 3.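

In this assay, going by these compounds alone, the earlier compounds differ only in the saturated chain, so they say nothing about the aromatic ring that carries the methyl. Going from 4-methylphenyl to 4-fluorophenyl gives a 1.0-fold higher number from compound 1 to compound 4 (0.01 log units; within the scatter) and so lies within the scatter. On the core and chain of compound 1, methyl and fluoro at this aromatic carbon therefore cannot be told apart in this read-out, and nothing shown offers a reason for that result.

Still open, as far as these compounds go, is whether a different kind of group on this carbon, such as an amine, a carboxylic acid or a methoxy group, would move the number beyond the scatter. From the compounds shown here alone, it is also open whether the same swap would read alike on the chain of compound 2.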